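Benzyl in place of allyl: cytotoxicity working notes

The compounds below may be only part of what the source reports. "The series", "measured", "known", "first", "only" and "open" are said of these compounds alone.

Measured compounds in a functional assay on A549 cells (Homo sapiens) for cytotoxicity, read by MTT assay, with a stated time of 48 h; on this read-out lower numbers stand for stronger inhibition and higher numbers for weaker inhibition:
compound 1, `Cc1nnc(SCc2ccccc2)n1N1C(=O)c2ccccc2C1=O` — > 200000 nM (a limit)
compound 2, `CCc1nnc(SCc2ccccc2)n1N1C(=O)c2ccccc2C1=O` — > 200000 nM (a limit)
compound 3, `C=CCSc1nnc(CCC)n1N1C(=O)c2ccccc2C1=O` — > 200000 nM (a limit)

Among the measured compounds shown here, every value so far in this assay is a limit rather than a number. Compound 3 stands at that limit, so no number places it against the others. For the measured compounds named here, the one step between measured compounds that differ in one place is a step that the two limits leave unreadable from compound 1 to compound 2: both ends are limits, so its size cannot be read. Going by the values given here, the only evidence available is the limit of > 200000 nM in this assay, at which 3 of the 3 values shown sit, and it gives no direction for any change on the shared core.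

Compound 4, `CCCc1nnc(SCc2ccccc2)n1N1C(=O)c2ccccc2C1=O`, is to be measured in this assay. Its difference from compound 3 is phenyl in place of vinyl on a saturated chain carbon bound to a sulfur. Compound 2 already carries benzylsulfanyl and sits at the limit, and compound 3 carries allylsulfanyl and sits at the limit, so the benzyl group alone has not brought any compound into the readable range. The step that the limit leaves unreadable from compound 3 to compound 4 is therefore expected to be none beyond the scatter, most likely a limit at both ends. Compound 4 is expected at 300000 nM, with a range from 100000 nM to 1000000 nM.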

Compound 4, half-maximal inhibitory concentration: > 200000 nM
Compound 4: no number, only a limit; the forecaster's own chance of this, stated with the estimate: 85%; the middle value does not contradict the limit.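

No new step can be read: compound 4 is also a limit, so the steps to it from compound 1, compound 2 and compound 3 have limits at both ends and their sizes cannot be read. Which change on the shared core, if any, would give a number in this assay stays open, and the only evidence remains: the limit of > 200000 nM in this assay, at which 4 of the 4 values shown sit.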